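This account rests on a few compounds, and the source may have more. Where it says the series, first, only, none or still open, it means among the compounds named here.

Measured compounds:
- compound 1, `COc1ccc(CO/N=C/c2c(C)nn(C)c2Oc2ccc(Cl)cc2)cc1`: 37%
- compound 2, `Cc1nn(-c2ccccn2)c(Oc2ccccc2)c1/C=N/OCc1ccc(C(=O)OC(C)(C)C)cc1`: -14.8%

In a functional assay on MCF7 cells (Homo sapiens) for antiproliferative activity, tested at 1 uM (a higher number here means more inhibition at the concentration tested (going by the name of the read-out), a lower number less inhibition), compound 1 gives 37%, and this is the highest of the two numbers measured. The nearest number belongs to compound 2, which in this assay gives -14.8%, a result a good deal lower and beyond the usual scatter. Going by the values given here, no single-change step between compound 1 and compound 2 is available, since the two structures differ in more than one place, so their values show only that the two differ.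

The next compound, compound 3 with the structure `Cc1nn(C)c(Oc2ccc(Cl)cc2)c1/C=N/OCc1ccc(C(F)(F)F)cc1`, differs from compound 1 in exactly one place: trifluoromethyl in place of methoxy on an aromatic carbon. The trifluoromethyl enters on an aromatic carbon of a six-membered aromatic ring of carbon only, where the methoxy of compound 1 stood.

Among the compounds with values here, there is no measured step of this kind to lean on. The step is expected to be small, of about a number 2 percentage points lower from compound 1 to compound 3 (within the scatter), with no clear direction beyond the scatter. Compound 3 is therefore estimated to give 35% in this assay, within a range from 10% to 60%.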

Compound 3, a percentage reported as inhibition, at one concentration (the size of the read-out at that concentration, not a potency): 16.4%
Estimate against measurement, compound 3: 18.6 percentage points above; low and high end bracket the measured number.
By their numbers in this assay, from the lowest: compound 2; then compound 3; then compound 1.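

Swapping methoxy for trifluoromethyl on an aromatic carbon, para to a large group, with the rest of the structure unchanged, gives a number 20.6 percentage points lower from compound 1 to compound 3 (beyond the scatter) in this assay. Going by these compounds alone, this is the first change in the set that can be read on its own, and it shows that the group at this position matters to the read-out: of the two groups compared here, methoxy goes with the higher number, although this rests on a single pair of compounds tested at one concentration. Nothing measured here bears on why the number moves in this way.

As far as these compounds go, it remains open how other groups at this position would compare, for example a hydroxyl, an amine or a single chlorine, and whether the order follows any trend or is particular to these two groups. From the compounds shown here alone, it is also open whether the same swap would give a step of similar size with other groups elsewhere on the core, or at concentrations other than the one used here.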